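A Carbonyl Substituent Swap Without a Measured Precedent

This account rests on a few compounds, and the source may have more. Where it says the series, first, only, none or still open, it means among the compounds named here.

Measured compounds:
Compound 1 `O=C(Nc1cccc(-n2cc(-c3ccncc3)c(-c3cc(O)cc(Cl)c3)n2)c1)Nc1ccc(Cl)c(C(F)(F)F)c1` gives -27%
Compound 2 `O=C(Nc1cccc(-n2cc(-c3ccncc3)c(-c3cc(O)cc(Cl)c3)n2)c1)Nc1ccc(Cl)c(Cl)c1` gives -11%
Compound 3 `COc1cc(Cl)cc(-c2nn(-c3cccc(NC(=O)Nc4ccc(Cl)c(C(F)(F)F)c4)c3)cc2-c2ccncc2)c1` gives -58%

All three were tested in a functional assay on SF-268 cells (Homo sapiens) for inhibition, read by sulforhodamine B assay, with a stated time of 48 h, tested at 100 uM; on this read-out lower numbers stand for a stronger effect and higher numbers for a weaker effect at the one concentration tested. On these numbers compound 3 stands lowest, and so shows the strongest effect: its nearest neighbour is compound 1, and compound 2 lies furthest away. Two single changes link the set. Going a number 16 percentage points higher from compound 1 to compound 2 (beyond the scatter) weakened the effect; going a number 31 percentage points lower from compound 1 to compound 3 (beyond the scatter) strengthened it markedly.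

Compound 4 `COc1cc(Cl)cc(-c2nn(-c3cccc(NC(=O)c4cccc(C(F)(F)F)c4)c3)cc2-c2ccncc2)c1` is the next member. It differs from compound 3 in one place: 3-(trifluoromethyl)phenyl in place of (4-chloro-3-(trifluoromethyl)phenyl)amino on a carbonyl carbon. Neither measured step covers this change. The step from compound 1 to compound 2 altered a halogen on the very ring that is now removed along with its amino link, and the step from compound 1 to compound 3 touched a different part of the molecule. The methoxy group that made compound 3 the strongest is kept, but the hydrogen-bond donor on the departing group is lost, so the direction of the outcome in this assay is uncertain. Compound 4 is therefore expected to give -30%, within a wide range from -65% to 5%, which means an expected step of a number 28 percentage points higher from compound 3 to compound 4 (beyond the scatter) toward a weaker effect.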

Compound 4, a percentage reported as activity, at one concentration (the size of the read-out at that concentration, not a potency): 58%
For compound 4 the middle estimate is 88 percentage points below the measured one; measured number outside the range, above it.
By their numbers in this assay, from the lowest: compound 3; then compound 1; then compound 2; then compound 4.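

Exchanging the (4-chloro-3-(trifluoromethyl)phenyl)amino group on the carbonyl carbon for 3-(trifluoromethyl)phenyl produces the largest step yet seen in this assay, namely a number 116 percentage points higher from compound 3 to compound 4 (beyond the scatter), and the sign of the read-out flips. Among the compounds shown here, the earlier compounds varied only a halogen-bearing group on the outer ring or the group on the oxygen, so this is the first sign that the read-out depends so heavily on what sits on this carbonyl carbon, and that keeping the methoxy group does not preserve the effect of compound 3. The departing group differs from the entering one in its amino link, with its hydrogen-bond donor, and in its chlorine, but nothing shown explains why the change has such a large effect.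

From the compounds shown here alone, since the amino link and the chlorine leave together, their separate contributions remain unknown; a 4-chloro-3-(trifluoromethyl)phenyl group placed directly on the same carbonyl carbon would keep the chlorine without the amino link. Going by these compounds, it also remains open whether a methylene link in place of the amino link would give a read-out closer to that of compound 3 or compound 4.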